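The source may report more compounds than this note shows. Statements on the series, on what has been measured and on what is new or still open speak of the compounds shown alone.

Compound 1 `O=C(Nc1ccc(Cl)c(-c2nnc3c(Cl)cccn23)c1)c1ccccc1Cl` was tested in a functional assay on AN3-CA cells (Homo sapiens) for antiproliferative activity, read by MTT assay, with a stated time of 72 h (a higher number here means a weaker inhibitor, a lower number a stronger inhibitor), where it gives only a limit, > 100000 nM. Compound 2 `O=C(Nc1ccc(Cl)c(-c2nnc3c(Cl)cccn23)c1)c1ccc(Cl)cc1Cl` carries a chloro in place of hydrogen on an aromatic carbon, and in this assay compound 2 gives 84800 nM. That step, an at least 1.1-fold lower number from compound 1 to compound 2 (0.07 log units; that floor lies within the scatter), is the only measured one, and its true size is not known because compound 1 sits at the limit of > 100000 nM in this assay, at which 1 of the 2 values shown sits. Going by the values given here, compound 2 thus holds the only actual number in this set; the other entry is a limit. Compound 3 `O=C(Nc1ccc(Cl)c(-c2nnc3c(Cl)cccn23)c1)c1cccnc1Cl` has not yet been measured. It differs from compound 2 in one place: 2-chloropyridin-3-yl in place of 2,4-dichlorophenyl on a carbonyl carbon. Among the compounds with values here, no measured step exchanges one aromatic ring for another, so the single step that adds a chlorine offers no direct guide, and that step in any case did not clear the scatter. The expectation is therefore a step of a 1.0-fold higher number from compound 2 to compound 3 (0.00 log units; within the scatter), which is none beyond the scatter. Compound 3 is estimated at 85000 nM in this assay, with a range from 30000 nM to 250000 nM.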

Compound 3, half-maximal inhibitory concentration: > 100000 nM
Compound 3 ended at the assay's limit (the forecaster's own chance of this, stated with the estimate: 40%); middle value at least 1.1-fold (0.07 log units) away from the limit.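

Placing 2-chloropyridin-3-yl on the carbonyl carbon in place of 2,4-dichlorophenyl gives an at least 1.1-fold higher number from compound 2 to compound 3 (0.07 log units; that floor lies within the scatter), so in this assay this exchange brings no improvement, although the true size of the step remains unknown. The earlier pair changed only a chlorine on a ring of carbon alone, whereas compound 3 brings to this position a ring with 1 hetero atom and 1 hydrogen-bond acceptor, and this change does not yield a lower number. The step between compound 1 and compound 3 cannot be read, and compound 2 remains the only compound with an actual number, because the other two entries are limits: the limit of > 100000 nM in this assay, at which 2 of the 3 values shown sit.

The compounds shown cover only chlorinated phenyl and chloropyridinyl rings on this carbonyl carbon, so it remains open whether a quite different group there, such as a morpholine, a carboxylic acid or a longer alkyl chain, would give a clearly lower number. On these data alone, it also remains open whether a pyridine ring without its chlorine would behave like 2-chloropyridin-3-yl in this assay.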